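This account rests on a few compounds, and the source may have more. Where it says the series, first, only, none or still open, it means among the compounds named here.

Working notes on the series. `COc1ccc(Nc2ccc3c(c2)C(=O)N(C2CCC(=O)NC2=O)C3=O)cc1` is compound 1; in an assay on FRT-Jurkat cells for inhibition of nuclear factor NF-kappa-B complex (Homo sapiens), read by flow cytometry, with a stated time of 24 h, tested at 10 uM (on this read-out lower numbers stand for less inhibition and higher numbers for more inhibition at the one concentration tested (going by the name of the read-out)), compound 1 gives 29%, the highest of the three numbers shown, with compound 3 nearest and compound 2 furthest. `O=C1CCC(N2C(=O)c3cccc(Nc4ccccn4)c3C2=O)C(=O)N1` is compound 2, which in this assay gives 1%. `O=C1CCC(N2C(=O)c3cccc(Nc4ccc(O)cc4)c3C2=O)C(=O)N1` is compound 3, which in this assay gives 4%. For the measured compounds named here, the one measured step, a number 3 percentage points higher from compound 2 to compound 3 (within the scatter), changes the aryl group on the nitrogen and leaves the methoxy of compound 1 untouched. Compound 4, `CCCCCc1ccc(Nc2ccc3c(c2)C(=O)N(C2CCC(=O)NC2=O)C3=O)cc1`, differs from compound 1 as follows: pentyl in place of methoxy on an aromatic carbon. Going by the values given here, no measured step bears on this change. The step expected is therefore none beyond the scatter, a number 1 percentage points higher from compound 1 to compound 4 (within the scatter), with a wide range around it. In this assay compound 4 is expected to give 30%, between 10% and 55%.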

Compound 4, a percentage reported as inhibition, at one concentration (the size of the read-out at that concentration, not a potency): 12%
Estimate against measurement, compound 4: 18 percentage points above; the measured number falls inside the stated range.
By their numbers in this assay, from the lowest: compounds 2, 3 and 4 (each within the scatter of the next, the first and the last beyond it); then compound 1.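

Pentyl in place of methoxy on this aromatic carbon gives a number 17 percentage points lower from compound 1 to compound 4 (beyond the scatter) in this assay so the group here, para to a large group, does change the read-out at the one concentration tested. For the compounds shown here, the earlier step, on the nitrogen, stayed within the scatter, and this is the first single change that does not. Nothing measured accounts for the drop. As far as these compounds go, whether an amine, a carboxylic acid, or a shorter or longer chain on this carbon would match compound 1 stays open.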